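A few compounds are considered here, and "the series" means these few. Any claim that something is new, unique, unknown or untested is made for them only; others in the source may bear on it.

Working notes on the series. Compound 1 `CCS[C@@H]1[C@H](SCC)[C@@H](Cn2cc(-c3ccccc3)nn2)O[C@H]1n1ccc(=O)[nH]c1=O` has no result in a functional assay on LAC cells (Homo sapiens) for cytotoxicity, read by MTT assay, with a stated time of 72 h; on this read-out higher numbers stand for an effect only at larger amounts of compound and lower numbers for an effect already at smaller amounts; compound 1 is recorded as "not determined" (no result reported). Compound 2 `CCS[C@@H]1[C@H](SCC)[C@@H](Cn2cc(-c3ccc(C)cc3)nn2)O[C@H]1n1ccc(=O)[nH]c1=O` carries the 4-methylphenyl group on an aromatic carbon of a five-membered aromatic ring with 3 nitrogen. In this assay compound 2 gives only a limit of the assay, >= 100000 nM, and no single number. The only bounded entry in the set is thus the limit (the limit of >= 100000 nM in this assay, at which 1 of the 2 values shown sits), so compound 2 stands alone, with nothing measured that it can be set against. Compound 3 `CCS[C@@H]1[C@H](SCC)[C@@H](Cn2cc(-c3cccc(C)c3)nn2)O[C@H]1n1ccc(=O)[nH]c1=O` differs by 3-methylphenyl in place of 4-methylphenyl on an aromatic carbon. Going by the values given here, no measured step exists in the set, so the size of such a change in this assay cannot be read from these data. The expectation for compound 3 is that this assay again reports a limit rather than a number, an estimate of 100000 nM with a range from 30000 nM to 300000 nM. The expected step is therefore a number no higher from compound 2 to compound 3 (the limit leaves the size open), none beyond the scatter.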

Compound 3, half-maximal effective concentration: 99000 nM
Compound 3: middle estimate off by 1.0-fold (0.00 log units), on the high side, and the stated range covers the measured number.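

In this assay, going by these compounds alone, compound 3 gives 99000 nM, the first single number, so 3-methylphenyl in place of 4-methylphenyl on an aromatic carbon yields a reading where compound 2 gave none. Compound 2 remains a limit of the assay, >= 100000 nM. The change reads as a number no higher from compound 2 to compound 3 (the limit leaves the size open), and any comparison at this position stays bounded by one entry: the limit of >= 100000 nM in this assay, at which 1 of the 3 values shown sits.

On these data alone, whether another group at this position can bring the effect to clearly smaller amounts in this assay remains open. The compounds shown do not tell what an amine or a carboxylic acid on the six-membered aromatic ring, or a longer chain in place of the methyl, would do to the number.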